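Swapping sec-Butyl for 2-(tert-Butoxycarbonyl)ethyl

A few compounds are considered here, and "the series" means these few. Any claim that something is new, unique, unknown or untested is made for them only; others in the source may bear on it.

Two closely related compounds have been tested so far in a functional assay on MCF7 cells (Homo sapiens) for inhibition, read by MTT assay, with a stated time of 72 h; on this read-out lower numbers stand for stronger inhibition and higher numbers for weaker inhibition. Compound 1 `C[C@H](NC(=O)c1cc(Cl)ccc1OCCNC(=O)OC(C)(C)C)C(=O)Nc1ccc([N+](=O)[O-])cc1Cl` gives > 10000 nM, which is a limit of the assay and not a number. Among the compounds with values here, compound 2 `CC[C@@H](C)[C@H](NC(=O)c1cc(Cl)ccc1OCCNC(=O)OC(C)(C)C)C(=O)Nc1ccc([N+](=O)[O-])cc1Cl` gives 10500 nM, the only actual number available, so there is no measured value to rank it against.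

Compound 3 `CC(C)(C)OC(=O)CC[C@H](NC(=O)c1cc(Cl)ccc1OCCNC(=O)OC(C)(C)C)C(=O)Nc1ccc([N+](=O)[O-])cc1Cl` keeps the shared core and changes one side chain: 2-(tert-butoxycarbonyl)ethyl in place of sec-butyl on a saturated chain carbon bound to an amide-type nitrogen and a carbonyl carbon. Within the data shown here, the same place was altered in the only measured step that bears on this change, a step that the limit leaves unreadable from compound 1 to compound 2. With no readable size, that step offers no scale for judging a new side chain, and it gives no direction either.

The expectation therefore rests on compound 2 alone, at 10500 nM, and no change beyond the usual scatter is predicted in this assay. The estimated step is a 1.0-fold higher number from compound 2 to compound 3 (0.02 log units; within the scatter). Compound 3 may again be reported only as a limit. If a number is obtained, compound 3 is expected at 11000 nM, within an estimated range of 4000 nM to 30000 nM.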

Compound 3, half-maximal inhibitory concentration: > 10000 nM
Compound 3: no number, only a limit; the forecaster's own chance of this, stated with the estimate: 50%; the middle value lies beyond the limit too.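

In this assay compound 3 gives > 10000 nM, which is a limit and not a number, so the steps from compound 1 and compound 2 to compound 3 cannot be read: the limit of > 10000 nM in this assay, at which 2 of the 3 values shown sit.

The compounds shown leave open how far compound 1 and compound 3 really lie from compound 2, and so whether the side chain at this place matters at all in this assay.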